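A few compounds are considered here, and "the series" means these few. Any claim that something is new, unique, unknown or untested is made for them only; others in the source may bear on it.

Three members of this series have been run in a functional assay on MDA-MB-468 cells (Homo sapiens) for cytotoxicity, read by sulforhodamine B assay, with a stated time of 48 h; on this read-out lower numbers stand for stronger inhibition of growth and higher numbers for weaker inhibition of growth. Compound 1 `CCN(CC)CN1C(=O)/C(=N\c2nc3ccc(C)cc3s2)c2c(Br)cccc21` gives 43100 nM. Compound 2 `Cc1ccc2nc(/N=C3\C(=O)N(CN4CCCCC4)c4ccccc43)sc2c1` gives 65600 nM. Compound 3 `Cc1ccc2nc(/N=C3\C(=O)N(CN(c4ccccc4)c4ccccc4)c4cccc(Br)c43)sc2c1` gives 82300 nM, the highest of the three numbers, yet its gaps to compound 2 and to compound 1 both lie within the scatter of repeated measurements, so no order among the three can be read from these values. Compound 4 `Cc1ccc2nc(/N=C3\C(=O)N(CN(c4ccccc4)c4ccccc4)c4cccc(Cl)c43)sc2c1` has not yet been measured; it differs from compound 3 by chloro in place of bromo on an aromatic carbon. For the measured compounds named here, no measured pair shows this exchange, so its effect here is not known. Such a change is expected to move the number little, in no set direction, and not beyond the scatter. For compound 4 the estimate is 85000 nM, with a range from 40000 nM to 180000 nM. The implied step a 1.0-fold higher number from compound 3 to compound 4 (0.01 log units; within the scatter) is expected to stay within the scatter.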

Compound 4, concentration for 50% growth inhibition: 85000 nM
The estimate for compound 4 equals the measured number at the digits printed; low and high end bracket the measured number.
By their numbers in this assay, from the lowest: compounds 1, 2, 3 and 4 (each within the scatter of the next).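

Chloro in place of bromo on this aromatic carbon gives a 1.0-fold higher number from compound 3 to compound 4 (0.01 log units; within the scatter) in this assay, the first step in the series between compounds that differ in one place. With the rest of the structure held constant, this read-out does not separate the two halogens at this position. No measured property bears on this result.

Going by these compounds, whether a methoxy group, an amine or a carboxylic acid on this carbon would move the number remains open. Also open, on these data alone, is whether the same exchange stays as flat with a diethylamino or piperidine group in place of the diphenylamino group.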